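The source may hold more compounds than are shown below. What is called first, only, known or untested is meant among the compounds shown, and "the series" means these compounds.

Working notes on the adenine-type series in a functional assay on the whole organism with Rattus norvegicus as the target, in the maximal electroshock model; on this read-out lower numbers stand for an effect already at smaller amounts and higher numbers for an effect only at larger amounts of compound.

Two members with a methylamino substituent are active: compound 1 `CNc1ncnc2c1ncn2Cc1ccccc1Cl` gives 6.2 mg/kg in this assay, and compound 2 `CNc1ncnc2c1ncn2Cc1cc(F)ccc1F` gives 4 mg/kg. Compound 3 `CC(C)(C)Nc1ncnc2c1ncn2Cc1ccccc1F` carries a (tert-butyl)amino group in place of methylamino. For compound 3 this assay reports only a limit, > 50 mg/kg. Among the compounds with values here, compound 3 is thus the one member sitting at the limit of > 50 mg/kg in this assay, at which 1 of the 3 values shown sits, and stands apart from compounds 1 and 2, whose values are within the scatter of each other.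

Compound 4 `Fc1ccccc1Cn1cnc2c(N3CCCC3)ncnc21` is the next member awaiting measurement. It differs from compound 3 by pyrrolidin-1-yl in place of (tert-butyl)amino on an aromatic carbon; in words, pyrrolidin-1-yl in place of (tert-butyl)amino on an aromatic carbon. Within the data shown here, no measured pair carries this change, so its effect has to be guessed from compound 3 alone. The step of an at least 1.4-fold lower number from compound 3 to compound 4 (0.15 log units; that floor lies within the scatter) is expected to run, if anywhere, toward smaller doses, but not clearly beyond the scatter. Compound 4 is accordingly estimated at 35 mg/kg in this assay, with a range from 8 mg/kg to 100 mg/kg, and a real chance that this assay again reports only a limit.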

Compound 4, dose for half-maximal effect: 12.5 mg/kg
Estimate against measurement, compound 4: 2.8-fold (0.45 log units) above, and the stated range covers the measured number.
By their numbers in this assay, from the lowest: compounds 2, 1 and 4 (each within the scatter of the next, the first and the last beyond it). At a limit, above all of these: compound 3.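

Within the data shown here, the exchange gives an at least 4.0-fold lower number from compound 3 to compound 4 (0.60 log units; beyond the scatter) in this assay, the first change that can be read at this position, on an aromatic carbon of the shared core. Both groups have the same count of heavy atoms, so the difference beyond the scatter comes with a five-membered non-aromatic ring and the loss of the hydrogen-bond donor, and this single pair cannot separate the two. The size of the step is only a floor, as compound 3 stands at a limit and not at a number: the limit of > 50 mg/kg in this assay, at which 1 of the 4 values shown sits.

The compounds shown leave open whether the ring or the missing donor matters, which dimethylamino, an open-chain group without the donor, or piperidin-1-yl could help to settle. Among these compounds, they also hold no pair comparing pyrrolidin-1-yl with methylamino on an otherwise identical compound.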